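Extending the alkyl triazole substituent into a pentylphenyl group

A few compounds are considered here, and "the series" means these few. Any claim that something is new, unique, unknown or untested is made for them only; others in the source may bear on it.

The shared core appears in compound 1, `O=C1O[C@H]([C@@H](O)Cn2cc(-c3cccc(O)c3)nn2)C(OCc2ccccc2)=C1OCc1ccccc1`, and compound 2, `CCCCc1cn(C[C@H](O)[C@H]2OC(=O)C(OCc3ccccc3)=C2OCc2ccccc2)nn1`. In a functional assay on A549 cells (Homo sapiens) for antiproliferative activity, read by MTT assay, with a stated time of 72 h (on this read-out higher numbers stand for weaker inhibition and lower numbers for stronger inhibition), compound 1 gives 59900 nM, while compound 2 gives 28600 nM, the lower of the two numbers and so the stronger inhibitor here. Going by the values given here, the only measured step is a 2.1-fold lower number from compound 1 to compound 2 (0.32 log units; beyond the scatter). Compound 3, `CCCCCc1ccc(-c2cn(C[C@H](O)[C@H]3OC(=O)C(OCc4ccccc4)=C3OCc3ccccc3)nn2)cc1`, has not been measured; it differs from compound 2 by 4-pentylphenyl in place of butyl on an aromatic carbon. Among the compounds with values here, no measured step covers this same exchange, so the single step from compound 1 to compound 2 is the only guide, and it shows that altering the group on that carbon of the five-membered ring can shift this assay modestly. A modest move in the same direction is therefore expected, though with wide uncertainty, giving an estimated step of a 1.9-fold lower number from compound 2 to compound 3 (0.28 log units; within the scatter). Compound 3 is thus estimated at 15000 nM, with a range from 5000 nM to 45000 nM.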

Compound 3, half-maximal inhibitory concentration: 6220 nM
Compound 3: middle estimate off by 2.4-fold (0.38 log units), on the high side, within the range that was stated.
By their numbers in this assay, from the lowest: compound 3; then compound 2; then compound 1.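

In this assay, the aromatic carbon of the five-membered ring accepts a far larger group than butyl, and the change to 4-pentylphenyl gives a 4.6-fold lower number from compound 2 to compound 3 (0.66 log units; beyond the scatter), a bigger move than the earlier step had shown. Compound 1 and compound 3 both carry a phenyl ring at this carbon, yet 4-pentylphenyl in place of 3-hydroxyphenyl gives a 9.6-fold lower number from compound 1 to compound 3 (0.98 log units; beyond the scatter), so the presence of a phenyl ring alone does not set the number, and butyl in compound 2 falls between the two. Nothing available explains why these groups rank in this order.

The three compounds do not separate the share of the phenyl ring from that of the pentyl chain, which an unsubstituted phenyl or a straight pentyl group at this carbon would address. They also leave open how a longer chain, such as octyl, or an amine on the phenyl ring would read in this assay.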